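Nitrophenyl for Fluorophenyl on the Piperazine Tail

This account rests on a few compounds, and the source may have more. Where it says the series, first, only, none or still open, it means among the compounds named here.

Compound 1 `CCCCCCCCn1cc(/C=C/C(=O)c2ccc(NC(=O)CN3CCN(c4ccccc4F)CC3)cc2)nn1`: 68600 nM in a functional assay on MCF7 cells (Homo sapiens) for inhibition, read by MTT assay; on this read-out lower numbers stand for stronger inhibition and higher numbers for weaker inhibition
Compound 2 `CCCCCCCCn1cc(/C=C/C(=O)c2ccc(N)cc2)nn1`: 31000 nM
Compound 3 `O=C(CN1CCN(c2ccccc2F)CC1)Nc1ccc(C(=O)/C=C/c2cn(Cc3ccc(Br)cc3)nn2)cc1`: 11300 nM

Compound 1 stands highest of the three numbers in this assay; compound 2 gives the nearest value and compound 3 the furthest. Compound 4 `CCCCCCCCn1cc(/C=C/C(=O)c2ccc(NC(=O)CN3CCN(c4ccc([N+](=O)[O-])cc4)CC3)cc2)nn1` differs from compound 1 in one place: 4-nitrophenyl in place of 2-fluorophenyl on an amine nitrogen in a ring. Among the compounds with values here, no measured step touches the amine nitrogen in the ring; the one single-site step, a 6.1-fold lower number from compound 1 to compound 3 (0.78 log units; beyond the scatter), concerns a different position and so offers no direct guidance. The expectation for compound 4 therefore rests on compound 1 alone, and the step is expected to be a 1.4-fold lower number from compound 1 to compound 4 (0.14 log units; within the scatter), probably within the scatter. Compound 4 is estimated at 50000 nM in this assay, with a range of 15000 nM to 150000 nM.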

Compound 4, half-maximal inhibitory concentration: 49100 nM
Compound 4: the middle estimate sits 1.0-fold (0.01 log units) above what was measured; the measured number falls inside the stated range.
By their numbers in this assay, from the lowest: compound 3; then compounds 2, 4 and 1 (each within the scatter of the next, the first and the last beyond it).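

In this assay, the change to 4-nitrophenyl in place of 2-fluorophenyl on an amine nitrogen in a ring gives a 1.4-fold lower number from compound 1 to compound 4 (0.15 log units; within the scatter) and so stays within the scatter. Within the data shown here, this is the first reading at this position, which the earlier step did not touch, and it shows that a larger aromatic group carrying hydrogen-bond acceptors leaves the number essentially where it was. No measurement shown here accounts for this outcome.

Still open, on these data alone, is whether a simple amine or a carboxylic acid on that phenyl ring would shift the number beyond the scatter. As far as these compounds go, it is also open whether the same change would hold alongside the 4-bromophenyl group of compound 3.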